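The compounds below may be only part of what the source reports. "The series", "measured", "known", "first", "only" and "open" are said of these compounds alone.

Compound 1, `C=CC(=O)Nc1ccc(Cn2nc(-c3ccc(Oc4ccccc4)cc3)cc2CO)cc1`: 8000 nM.
Compound 2, `CCOC(=O)c1cc(-c2ccc(Oc3ccccc3)cc2)nn1Cc1ccc(NC(=O)CCl)cc1`: 400 nM.

Of the compounds shown here, two have so far been measured in a functional assay on JeKo-1 cells (Homo sapiens) for inhibition, read by luminescence and CellTiter-Glo, with a stated time of 72 h; a higher number here means a weaker inhibitor, a lower number a stronger inhibitor. Compound 2 holds the lowest of the two numbers; compound 1 gives a much higher number, and the gap between them lies beyond the usual scatter. Compound 3, `O=C(CCl)Nc1ccc(Cn2nc(-c3ccc(Oc4ccccc4)cc3)cc2CO)cc1`, is still to be measured. Compared with compound 2 it changes in one place: hydroxymethyl in place of ethoxycarbonyl on an aromatic carbon. Going by the values given here, no measured pair shows this change on its own. Compound 1 also carries hydroxymethyl, yet it differs from compound 2 in more than one place, so its weaker value cannot be laid to this change alone. Still, a loss of potency is the most plausible expectation, and the step from compound 2 to compound 3 is estimated as a 3.8-fold higher number from compound 2 to compound 3 (0.57 log units; beyond the scatter), beyond the scatter. Compound 3 is therefore expected to give about 1500 nM in this assay, with a likely range from 400 nM to 6000 nM.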

Compound 3, half-maximal inhibitory concentration: 400 nM
Beside the measured number, compound 3's estimate is 3.8-fold (0.57 log units) above it; low and high end bracket the measured number.
By their numbers in this assay, from the lowest: compounds 2 and 3 (each within the scatter of the next); then compound 1.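

In this assay the aromatic carbon next to the ring nitrogen accepts a clear change of group: hydroxymethyl in place of ethoxycarbonyl gives no change at the digits printed from compound 2 to compound 3 (within the scatter) even though the group shrinks from 5 heavy atoms to 2. Compound 3 also makes a one-place comparison possible on the carbonyl carbon, where chloromethyl in place of vinyl gives a 20-fold lower number from compound 1 to compound 3 (1.30 log units; beyond the scatter) and so ties the weak value of compound 1 to its vinyl group rather than to the hydroxymethyl that compound 3 shares. No measurement available here explains either result.

Going by these compounds, whether a carboxylic acid, an amine or a longer chain on this aromatic carbon would also leave the number unchanged remains open. So does whether vinyl and chloromethyl would differ as widely with ethoxycarbonyl on the ring.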